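Bromo in Place of Hydrogen: Expected Cytotoxicity of Compound 4

The compounds below may be only part of what the source reports. "The series", "measured", "known", "first", "only" and "open" are said of these compounds alone.

Compound 1 `c1ccc(-c2nnc(-c3ccc(-n4cccc4)cc3)o2)cc1`: 250000 nM
Compound 2 `O=[N+]([O-])c1cccc(-c2nnc(-c3ccc(-n4cccc4)cc3)o2)c1`: 251000 nM
Compound 3 `O=C(NNC(=O)c1ccccc1[N+](=O)[O-])c1ccc(-n2cccc2)cc1`: 182000 nM

These three compounds were tested in an ADME assay on Vero cells (Chlorocebus sabaeus) for cytotoxicity, read by MTT assay, with a stated time of 72 h; a lower number here means a stronger inhibitor, a higher number a weaker inhibitor. Compound 1 gives 250000 nM, compound 2 gives 251000 nM and compound 3 gives 182000 nM. Compound 1 stands second highest of the three numbers; its nearest neighbour is compound 2 and its furthest is compound 3, and both gaps lie within the scatter, so the three compounds cannot be told apart on these numbers.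

Compound 4 `Brc1ccc(-c2nnc(-c3ccc(-n4cccc4)cc3)o2)cc1` has not yet been measured. It differs from compound 1 by bromo in place of hydrogen on an aromatic carbon. Among the compounds with values here, the only measured step that bears on this change is a 1.0-fold higher number from compound 1 to compound 2 (0.00 log units; within the scatter), where a nitro group replaced hydrogen on an aromatic carbon of the same core and the number did not move beyond the scatter. By analogy, the step from compound 1 to compound 4 is expected to stay within the scatter, a 1.3-fold lower number from compound 1 to compound 4 (0.10 log units; within the scatter). Compound 4 is therefore estimated at 200000 nM in this assay, with a range from 80000 nM to 400000 nM.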

Compound 4, half-maximal inhibitory concentration: 260000 nM
The estimate for compound 4 lay 1.3-fold (0.11 log units) below the measured number; the measured number falls inside the stated range.
By their numbers in this assay, from the lowest: compounds 3, 1, 2 and 4 (each within the scatter of the next).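

In this assay, bromo in place of hydrogen gives a 1.0-fold higher number from compound 1 to compound 4 (0.02 log units; within the scatter). This extends the picture to a new group at a specific place: a single bromine atom on an aromatic carbon, para to a large group, leaves the number within the scatter of compound 1, as the nitro group of compound 2 also did at its own place on the core. No measurement at hand explains this result.

The compounds shown leave open whether a group of a different kind at this same place, such as an amine or a carboxylic acid, would also stay within the scatter. They also leave open whether a longer chain there, such as a butyl group, would shift the number beyond the scatter.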